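A few compounds are considered here, and "the series" means these few. Any claim that something is new, unique, unknown or untested is made for them only; others in the source may bear on it.

Compound 1, whose structure is `CCc1sc(CCc2cc(OC)cc(NCc3cc(Cl)cc(NC(=O)OC(C)C)c3)n2)nc1C`, is the weaker of the two measured compounds in an assay on cells for binding affinity to Neuropeptide Y receptor type 1 (Homo sapiens) (a higher number here means a weaker inhibitor, a lower number a stronger inhibitor), where compound 1 gives 234 nM. For the measured compounds named here, the only comparison point is compound 2, `CCc1sc(CCc2cc(OCC3(C)CC3)cc(NCc3cc(Cl)cc(NC(=O)OC(C)C)c3)n2)nc1C`, which in this assay gives 17 nM. Going by the values given here, the single measured step, a 14-fold lower number from compound 1 to compound 2 (1.14 log units; beyond the scatter), shows that adding a carbon substituent on the saturated chain carbon bound to the oxygen on the aromatic ring can move the number strongly downward.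

Compound 3, with the structure `CCc1sc(CCc2cc(OCCCc3ccccc3)cc(NCc3cc(Cl)cc(NC(=O)OC(C)C)c3)n2)nc1C`, has not yet been measured. It differs from compound 1 as follows: phenethyl in place of hydrogen on a saturated chain carbon bound to an oxygen on an aromatic ring. The change sits at the same saturated chain carbon bound to an oxygen on an aromatic ring as the change from compound 1 to compound 2, so that step is the one that bears on it. Because the step of a 14-fold lower number from compound 1 to compound 2 (1.14 log units; beyond the scatter) was large and lowering, a lowering step beyond the scatter is expected here as well, though the phenethyl group is a different substituent from 1-methylcyclopropyl and the size is uncertain. Compound 3 is therefore estimated to give 30 nM in this assay, within a range of 8 nM to 110 nM, which corresponds to an expected step of a 7.8-fold lower number from compound 1 to compound 3 (0.89 log units; beyond the scatter).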

Compound 3, half-maximal inhibitory concentration: 20 nM
Estimate against measurement, compound 3: 1.5-fold (0.18 log units) above; the measured number falls inside the stated range.
By their numbers in this assay, from the lowest: compounds 2 and 3 (each within the scatter of the next); then compound 1.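

In this assay, phenethyl gives a 12-fold lower number from compound 1 to compound 3 (1.07 log units; beyond the scatter), so a second and quite different carbon substituent on the saturated chain carbon bound to an oxygen on an aromatic ring also comes with a large lowering step, and the effect seen with 1-methylcyclopropyl is no longer a single case. The direct comparison of the two substituents is a 1.2-fold higher number from compound 2 to compound 3 (0.07 log units; within the scatter), so this assay does not separate the phenethyl group, with its six-membered aromatic ring, from the 1-methylcyclopropyl group, although the two differ clearly in shape and ring type. Nothing available explains why these two different groups give such closely matching values.

The compounds shown leave open how far this tolerance extends, as both substituents contain carbon only and neither carries a hydrogen-bond donor or acceptor, so an amine or a carboxylic acid at the end of the chain could behave quite differently. From the compounds shown here alone, it also remains open whether a small ethyl group already gives much of the step, and whether a longer chain ending in the same phenyl ring keeps it.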